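The compounds below may be only part of what the source reports. "The series", "measured", "known", "first", "only" and "open" are said of these compounds alone.

Working notes on the series. Compound 3 `N[C@]1(C(=O)O)[C@H]2[C@@H](C[C@H]1OCc1cc(Cl)cc(Cl)c1)[C@]2(F)C(=O)O` is the reference point here. Within the data shown here, in an assay on CHO cells for binding affinity to metabotropic glutamate receptor 2 (Rattus norvegicus) (a lower number here means a stronger inhibitor, a higher number a weaker inhibitor), compound 3 gives 5.61 nM, the second highest of the three numbers measured so far. Compound 1 `N[C@]1(C(=O)O)[C@H]2[C@@H](C[C@H]1OCc1ccc(F)c(F)c1)[C@]2(F)C(=O)O` gives 2.27 nM in this assay, and the step of a 2.5-fold higher number from compound 1 to compound 3 (0.39 log units; beyond the scatter) separates the two. Compound 2 `N[C@]1(C(=O)O)[C@H]2[C@@H](C[C@H]1OCc1c(F)cccc1F)[C@]2(F)C(=O)O` gives 7.02 nM in this assay, and the step of a 1.3-fold lower number from compound 2 to compound 3 (0.10 log units; within the scatter) is too small to tell the two apart.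

The next compound, compound 4 `N[C@]1(C(=O)O)[C@H]2[C@@H](C[C@H]1OCc1cccs1)[C@]2(F)C(=O)O`, differs from compound 3 by thiophen-2-yl in place of 3,5-dichlorophenyl on a saturated chain carbon bound to an oxygen on a saturated carbon. Among the measured compounds shown here, none of the measured steps swaps a six-membered ring for a five-membered one; all three only rearrange halogens on the same kind of ring. Those steps were modest at most: a 3.1-fold higher number from compound 1 to compound 2 (0.49 log units; beyond the scatter) and a 2.5-fold higher number from compound 1 to compound 3 (0.39 log units; beyond the scatter), while a 1.3-fold lower number from compound 2 to compound 3 (0.10 log units; within the scatter) stays inside the scatter. The aryl group therefore seems to move this assay only modestly, so for compound 4 a step of a 1.4-fold higher number from compound 3 to compound 4 (0.15 log units; within the scatter) is expected, slightly toward a higher number, though a result inside the scatter would not surprise. The estimate for compound 4 in this assay is 8 nM, with a range from 3 nM to 25 nM.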

Compound 4, inhibition constant: 8.79 nM
Compound 4: middle estimate off by 1.1-fold (0.04 log units), on the low side; the measured number falls inside the stated range.
By their numbers in this assay, from the lowest: compound 1; then compounds 3, 2 and 4 (each within the scatter of the next).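

Thiophen-2-yl brings the first five-membered aromatic ring with a hetero atom to this position, and in this assay the change is small against two of the halogenated groups: a 1.6-fold higher number from compound 3 to compound 4 (0.20 log units; within the scatter) and a 1.3-fold higher number from compound 2 to compound 4 (0.10 log units; within the scatter) both stay inside the scatter. Losing the six-membered aromatic ring of carbon only, both halogens and some heavy atoms therefore leaves compound 4 indistinguishable from compound 2 and compound 3, while only a 3.9-fold higher number from compound 1 to compound 4 (0.59 log units; beyond the scatter) lies beyond the scatter, so compound 1, with its 3,4-difluorophenyl, remains apart from all three other compounds as the strongest inhibitor of the four. Nothing available here accounts for this pattern.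

Ring size and halogen loss change together in compound 4, so an unsubstituted phenyl would be needed to separate them. From the compounds shown here alone, it also remains open whether an amine or a carboxylic acid in place of the aryl group, or a longer chain carrying the ring on the oxygen, would keep the number in the range seen for these four compounds.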